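A few compounds are considered here, and "the series" means these few. Any claim that something is new, unique, unknown or untested is made for them only; others in the source may bear on it.

In a functional assay on MCF7 cells (Homo sapiens) for antiproliferative activity, read by MTT assay, with a stated time of 24 h (on this read-out higher numbers stand for weaker inhibition and lower numbers for stronger inhibition), two amides on one shared core have been measured so far. Compound 1 `COC(=O)c1scc(-c2ccc(NC(=O)c3ccc(F)c(Cl)n3)cc2)c1OC` gives 10300 nM, and compound 2 `COC(=O)c1scc(-c2ccc(NC(=O)c3ccc(C#N)nc3)cc2)c1OC` gives 9540 nM. These two numbers lie within the scatter of each other, so compound 2 stands level with compound 1 and cannot be ranked apart from it.

Compound 3 `COC(=O)c1scc(-c2ccc(NC(=O)c3ccc(OC)nc3)cc2)c1OC` keeps the core of compound 2 and alters a single group: methoxy in place of cyano on an aromatic carbon. This places methoxy in place of cyano on an aromatic carbon, turning 6-cyanopyridin-3-yl into 6-methoxypyridin-3-yl. Within the data shown here, only one measured step bears on this change, and it is an indirect guide. Going the other way along the series, a 1.1-fold lower number from compound 1 to compound 2 (0.03 log units; within the scatter), and this exchange of the whole group on the carbonyl carbon stayed within the scatter. Among the measured compounds shown here, no measured compound carries the methoxy group, so the evidence is thin. Even so, no step beyond the scatter is expected in this assay, and no direction can be favoured. The expected change is a 1.0-fold lower number from compound 2 to compound 3 (0.00 log units; within the scatter). Compound 3 is estimated at 9500 nM, with an expected range of 4500 nM to 20000 nM.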

Compound 3, half-maximal inhibitory concentration: 5250 nM
The estimate for compound 3 lay 1.8-fold (0.26 log units) above the measured number; measured number inside the range.
By their numbers in this assay, from the lowest: compounds 3, 2 and 1 (each within the scatter of the next).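

In this assay, the exchange on the aromatic carbon next to the ring nitrogen, para to a large group, gives a 1.8-fold lower number from compound 2 to compound 3 (0.26 log units; within the scatter), so compound 3 stands level with compound 2: at this position, methoxy and cyano, which match in heavy atoms and hydrogen-bond acceptors, cannot be told apart. The change of the whole group on the carbonyl carbon gives a 2.0-fold lower number from compound 1 to compound 3 (0.29 log units; within the scatter), so the three amides on the shared core still cannot be ranked, and a third group on the carbonyl carbon has now been seen without any step beyond the scatter. Nothing available here offers an explanation for these results.

The compounds shown leave open whether any group at this position can move the number beyond the scatter, for example an amine, a carboxylic acid or a longer chain such as butoxy in place of the methoxy of compound 3. They also leave open whether the number responds to changes elsewhere on the shared core, such as replacing the methyl ester with a carboxylic acid.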